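One Methylene Longer in the Chlorophenoxy Chain

The compounds below may be only part of what the source reports. "The series", "measured", "known", "first", "only" and "open" are said of these compounds alone.

Compound 3 `Cc1cc(C)c(NC(=O)C(C)(C)CCCCCOc2ccc(Cl)cc2)c2c1CC(C)(C)O2` gives the highest number of the three measured compounds in an assay for inhibition of acyl-CoA:cholesterol acyltransferase (Oryctolagus cuniculus), using microsomes (a lower number here means a stronger inhibitor, a higher number a weaker inhibitor), with 150 nM. Compound 1 `CCCCCCCCC(C)(C)C(=O)Nc1c(C)cc(C)c2c1OC(C)(C)C2` sits closest, at 140 nM, and a 1.1-fold higher number from compound 1 to compound 3 (0.03 log units; within the scatter). Compound 2 `CCCCCCCCCCCCC(C)(C)C(=O)Nc1c(C)cc(C)c2c1OC(C)(C)C2` lies furthest, at 33 nM, and a 4.5-fold higher number from compound 2 to compound 3 (0.66 log units; beyond the scatter). Compound 4 `Cc1cc(C)c(NC(=O)C(C)(C)CCCCCCOc2ccc(Cl)cc2)c2c1CC(C)(C)O2` differs from compound 3 in one place: (4-chlorophenoxy)methyl in place of 4-chlorophenoxy on a saturated chain carbon, six bonds along the chain from a carbonyl carbon. Among the compounds with values here, two measured steps bear on this. Lengthening the chain on the shared core helped in this assay: a 4.2-fold lower number from compound 1 to compound 2 (0.63 log units; beyond the scatter). Replacing a plain chain end with the chlorophenoxy group cost about as much: a 4.5-fold higher number from compound 2 to compound 3 (0.66 log units; beyond the scatter). Adding a single chain carbon is a far smaller change than the butyl added from compound 1 to compound 2, so only a small lowering of the number, near the edge of the scatter, is expected for compound 4 in this assay, a 1.5-fold lower number from compound 3 to compound 4 (0.18 log units; within the scatter). Compound 4 is therefore estimated at 100 nM, within a range of 45 nM to 230 nM.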

Compound 4, half-maximal inhibitory concentration: 76 nM
The estimate for compound 4 lay 1.3-fold (0.12 log units) above the measured number, and the stated range covers the measured number.
By their numbers in this assay, from the lowest: compound 2; then compounds 4, 1 and 3 (each within the scatter of the next).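

In this assay, the added chain carbon gives a 2.0-fold lower number from compound 3 to compound 4 (0.30 log units; within the scatter), so the two chlorophenoxy compounds stay within the scatter of each other and this change cannot be told apart from repeat measurement. The longer chlorophenoxy chain also stays within the scatter of the plain chain of compound 1, with a 1.8-fold lower number from compound 1 to compound 4 (0.27 log units; within the scatter), yet remains separated from the longer plain chain, with a 2.3-fold higher number from compound 2 to compound 4 (0.36 log units; beyond the scatter), a step beyond the scatter. No measurement at hand offers an explanation for these results.

The compounds shown leave open whether 2-(4-chlorophenoxy)ethyl or 3-(4-chlorophenoxy)propyl at this place would carry the number beyond the scatter of compound 3. They also leave open how a chain ending in an amine or a carboxylic acid, in place of the 4-chlorophenoxy end, would read in this assay.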